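One amide substituent exchanged in compound 1

This account rests on a few compounds, and the source may have more. Where it says the series, first, only, none or still open, it means among the compounds named here.

In a physicochemical assay for lipophilicity, at pH 7.4 (on this read-out lower numbers stand for lower lipophilicity and higher numbers for higher lipophilicity), compound 1 (`O=C(Nc1ccc2[nH]c(=O)[nH]c2c1)[C@H]1CCCN1C(=O)C1(c2cccc(Cl)c2)CCCC1`) gives 4.4 as its reading. On the same scale compound 2 (`O=C(Nc1ccc2[nH]ncc2n1)[C@H]1CCCN1C(=O)C1(c2ccc(Cl)cc2)CCC1`) gives 4.7 as its reading, so the two numbers lie within the usual scatter of each other. Compound 1 therefore has no measured neighbour separated from it beyond that scatter. Within the data shown here, no two measured compounds differ in one place only, so the data hold no direct guide to the size of the change considered here.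

Compound 3 (`CNC(=O)c1ccc(NC(=O)[C@H]2CCCN2C(=O)C2(c3cccc(Cl)c3)CCCC2)cc1`) has not yet been measured. It keeps the rest of compound 1 and carries a group of 10 heavy atoms (8 carbon, 1 nitrogen, 1 oxygen; one six-membered aromatic ring of carbon only) in place of a group of 10 heavy atoms (7 carbon, 2 nitrogen, 1 oxygen; one five-membered aromatic ring with 2 hetero atoms, one six-membered aromatic ring of carbon only), on an amide-type nitrogen and the entering group is 4-(methylcarbamoyl)phenyl. Among the measured compounds shown here, with no measured step to draw on, no change beyond the scatter is expected in this assay in either direction, and the reading of compound 1 at 4.4 serves as the starting point. The estimated step of no change at the digits printed from compound 1 to compound 3 (within the scatter) is expected to stay inside the scatter. Compound 3 is expected at 4.4 within a range of 3.9 to 4.9 on this estimate.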

Compound 3, distribution coefficient: 5.3
For compound 3 the middle estimate is 0.90 log units below the measured one; the measured number lies above the stated range.
By their numbers in this assay, from the lowest: compounds 1 and 2 (each within the scatter of the next); then compound 3.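

In this assay, among these compounds, placing 4-(methylcarbamoyl)phenyl on the amide-type nitrogen gives the first measured step in this set, a number 0.90 log units higher from compound 1 to compound 3 (beyond the scatter). This shows that the read-out responds to a change at this position even when the leaving and entering groups each hold 10 heavy atoms; the exchange removes the five-membered aromatic ring with 2 hetero atoms and goes from 2 hydrogen-bond donors to 1 hydrogen-bond donor. No measurement available here accounts for the size or direction of this step.

The compounds shown leave open whether the step belongs to the loss of the five-membered ring or to the methylcarbamoyl group itself, a question that a plain phenyl or a 4-carboxyphenyl group on the same amide-type nitrogen could help to separate. As far as these compounds go, it also remains open whether the exchange would give a similar step on another core, as compound 2 differs from compound 1 in more than one place and offers no second reading of this change.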